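This account rests on a few compounds, and the source may have more. Where it says the series, first, only, none or still open, it means among the compounds named here.

Measured compounds:
Compound 1, `COc1cc(-c2nn(-c3cccc(NC(=O)Nc4cc(C(F)(F)F)cc(C(F)(F)F)c4)c3)cc2-c2ccncc2)ccc1Cl`, gives 931 nM in a functional assay on HCC 2998 cells (Homo sapiens) for inhibition, read by sulforhodamine B assay, with a stated time of 48 h; on this read-out lower numbers stand for stronger inhibition of growth and higher numbers for weaker inhibition of growth.
Compound 2, `COc1cc(-c2nn(-c3cccc(NC(=O)c4cccc(C(F)(F)F)c4)c3)cc2-c2ccncc2)ccc1Cl`, gives 2240 nM in this assay.

Two compounds share a core and differ in the group that hangs from the carbonyl of the side-chain linker. Compound 2 stands at the higher of the two numbers in this assay, and its gap to compound 1 lies beyond the usual scatter, so compound 1 is the stronger grower-inhibitor of the pair.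

Compound 3, `COc1cc(-c2nn(-c3cccc(NC(=O)Nc4cccc(C(F)(F)F)c4)c3)cc2-c2ccncc2)ccc1Cl`, is not yet measured. It comes from compound 2 by one change: (3-(trifluoromethyl)phenyl)amino in place of 3-(trifluoromethyl)phenyl on a carbonyl carbon. The linker thereby turns from an amide into a urea, as in compound 1, while the ring keeps a single trifluoromethyl group.

For the measured compounds named here, no measured pair shows this step on its own. Compound 1, which carries both the urea and a second trifluoromethyl group, gives 931 nM, so the urea alone may bring part of that gain. The expected step from compound 2 to compound 3 is a 1.6-fold lower number from compound 2 to compound 3 (0.20 log units; within the scatter), toward stronger inhibition, though it may not clear the scatter. Compound 3 is therefore estimated at 1400 nM, in the range 500 nM to 4000 nM.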

Compound 3, concentration for 50% growth inhibition: 1190 nM
Estimate against measurement, compound 3: 1.2-fold (0.07 log units) above; measured number inside the range.
By their numbers in this assay, from the lowest: compounds 1, 3 and 2 (each within the scatter of the next, the first and the last beyond it).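

Compound 3 makes it possible to read the two structural differences between the urea with two trifluoromethyl groups and the amide with one as separate single changes. In this assay, putting (3-(trifluoromethyl)phenyl)amino in place of 3-(trifluoromethyl)phenyl on the carbonyl carbon gives a 1.9-fold lower number from compound 2 to compound 3 (0.27 log units; within the scatter), while hydrogen in place of trifluoromethyl on an aromatic carbon gives a 1.3-fold higher number from compound 1 to compound 3 (0.11 log units; within the scatter), so neither single change clears the usual scatter and neither can be singled out as decisive on its own. No measurement at hand explains why either change has the size it does.

The compounds shown leave open how far this growth inhibition depends on the group on the carbonyl, since a benzylamino group or a piperidine there could give a clearer reading than these two close neighbours. They also leave open whether the second trifluoromethyl group can be replaced at all, for instance by a chlorine atom or a nitrile, and whether either change would exceed the scatter when made on a different partner group.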